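The source may report more compounds than this note shows. Statements on the series, on what has been measured and on what is new or still open speak of the compounds shown alone.

Few firm readings exist for this small set of compounds, which share a common core. Within the data shown here, in a functional assay on MCF7 cells (Homo sapiens) for cytotoxicity, read by MTT assay, with a stated time of 48 h (on this read-out lower numbers stand for stronger inhibition and higher numbers for weaker inhibition), compound 1 `CC(C)n1c(/C=C2/C(=O)Nc3ccc(Br)cc32)nc2ccccc21` gives 14900 nM, the only true number so far. In this assay, compound 2 `CCn1c(/C=C2/C(=O)Nc3ccc(F)cc32)nc2ccccc21` gives > 50000 nM, and this is a limit of the assay, not a number. All it tells is that compound 2 has no measured value to stand on. For compound 3 `CCn1c(/C=C2/C(=O)Nc3ccccc32)nc2ccccc21` the entry reads "not determined" (no result reported), so it adds nothing to the comparison.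

The next compound to be tested is compound 4 `CC(C)n1c(/C=C2/C(=O)Nc3ccc(F)cc32)nc2ccccc21`. Its structure departs from compound 2 in one place: methyl in place of hydrogen on a saturated chain carbon bound to an aromatic nitrogen and a saturated chain carbon. Put simply, the ethyl group becomes an isopropyl group. Among the measured compounds shown here, no two measured compounds differ by a single change, so the data offer no direct measure of what such a step does. For the measured compounds named here, compound 1 at 14900 nM shows only that firm readings do occur in this set. A modest move toward stronger inhibition is therefore the cautious expectation, and the estimated step is an at least 1.6-fold lower number from compound 2 to compound 4 (0.22 log units; that floor lies within the scatter). A result that again reaches the limit would be no surprise. The expected value for compound 4 is 30000 nM, with an estimated range of 12000 nM to 60000 nM.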

Compound 4, half-maximal inhibitory concentration: 29000 nM
Beside the measured number, compound 4's estimate is 1.0-fold (0.01 log units) above it, and the stated range covers the measured number.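

In this assay, among these compounds, isopropyl in place of ethyl on the aromatic nitrogen's chain gives the first reading of this change: an at least 1.7-fold lower number from compound 2 to compound 4 (0.23 log units; that floor lies within the scatter). Compound 2 stands at a limit and not at a number, so this step is only a floor: the limit of > 50000 nM in this assay, at which 1 of the 4 values shown sits. Among the compounds that carry isopropyl, fluoro in place of bromo on an aromatic carbon gives a 1.9-fold higher number from compound 1 to compound 4 (0.29 log units; within the scatter), so in this assay these two groups cannot be told apart.

The compounds shown leave open whether a longer chain such as butyl, or a chain ending in an amine, would move the number in either direction when set in place of the isopropyl group. They also leave open what a chloro or methoxy group would do on the aromatic carbon that holds fluoro in compound 4.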